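The compounds below may be only part of what the source reports. "The series", "measured", "known", "first", "only" and "open" are said of these compounds alone.

In a functional assay on MCF7 cells (Homo sapiens) for inhibition, read by resazurin assay, with a stated time of 72 h (on this read-out lower numbers stand for stronger inhibition and higher numbers for weaker inhibition), compound 1 (`COc1cc(N2C(=O)CC2c2ccc(SC)cc2)cc(OC)c1OC`) gives 67 nM and compound 2 (`CCOc1ccc(C2C(C3CC3)C(=O)N2c2cc(OC)c(OC)c(OC)c2)cc1`) gives 131 nM. These two numbers lie within the usual scatter of each other, so neither compound stands apart. Compound 3 (`C=CC1C(=O)N(c2cc(OC)c(OC)c(OC)c2)C1c1ccc(SC)cc1`) differs from compound 1 in one place, with vinyl in place of hydrogen on a saturated ring carbon. Among the compounds with values here, no measured pair shows this change on its own, so the expectation is tentative. The estimated step, a 1.9-fold lower number from compound 1 to compound 3 (0.28 log units; within the scatter), is a modest one towards stronger inhibition in this assay. For compound 3 the expected value is 35 nM, with an estimated range of 10 nM to 120 nM.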

Compound 3, half-maximal inhibitory concentration: 51 nM
For compound 3 the middle estimate is 1.5-fold (0.16 log units) below the measured one; low and high end bracket the measured number.
By their numbers in this assay, from the lowest: compounds 3, 1 and 2 (each within the scatter of the next, the first and the last beyond it).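

Vinyl in place of hydrogen on this saturated ring carbon of the four-membered ring gives a 1.3-fold lower number from compound 1 to compound 3 (0.12 log units; within the scatter) in this assay, so this single change leaves the number within the usual scatter. This position can therefore carry vinyl, with its two added carbons, while the read-out stays in the same range as for compound 1. No accompanying measurement offers an explanation for this result.

This is one pair and one new group. From the compounds shown here alone, whether an amine, a carboxylic acid or a longer chain at this ring carbon would move the number beyond the scatter remains open.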